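The source may hold more compounds than are shown below. What is called first, only, known or untested is meant among the compounds shown, and "the series" means these compounds.

Measured so far in an assay on LtK cells with ATP-sensitive inward rectifier potassium channel 11 (Homo sapiens) as the target; on this read-out higher numbers stand for an effect only at larger amounts of compound and lower numbers for an effect already at smaller amounts:
- compound 1 `O=C(Nc1c(C(O)(C(F)(F)F)C(F)(F)F)ccc2ccccc12)C1CCCC1` gives 495 nM
- compound 2 `O=C(Nc1c(C(O)(C(F)(F)F)C(F)(F)F)ccc2ccccc12)c1ccccc1` gives 44 nM
- compound 3 `O=C(Nc1c(C(O)(C(F)(F)F)C(F)(F)F)ccc2ccccc12)c1ccccc1Cl` gives 2040 nM

Compound 3 stands highest of the three numbers: its nearest neighbour is compound 1, a 4.1-fold higher number from compound 1 to compound 3 (0.62 log units; beyond the scatter), and its furthest is compound 2, a 46-fold higher number from compound 2 to compound 3 (1.67 log units; beyond the scatter). Both steps lie beyond the scatter, so compound 3 is the weakest of the measured set in this assay.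

The next compound, compound 4 `O=C(Nc1c(C(O)(C(F)(F)F)C(F)(F)F)ccc2ccccc12)c1cccs1`, changes compound 3 at one place: thiophen-2-yl in place of 2-chlorophenyl on a carbonyl carbon. For the measured compounds named here, two measured steps bear on it. The step of a 46-fold higher number from compound 2 to compound 3 (1.67 log units; beyond the scatter) shows that adding chloro to the phenyl on the carbonyl carbon costs a large amount; compound 4 carries no chloro. The step of an 11-fold lower number from compound 1 to compound 2 (1.05 log units; beyond the scatter) shows that a flat aromatic group on the carbonyl carbon is favoured over cyclopentyl. Thiophen-2-yl is a five-membered aromatic ring with no chloro, so a large drop in number toward the value of compound 2 is expected. For compound 4 the expected step is a 26-fold lower number from compound 3 to compound 4 (1.41 log units; beyond the scatter). Compound 4 is therefore estimated at 80 nM, with a range from 20 nM to 400 nM.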

Compound 4, half-maximal effective concentration: 12 nM
Compound 4: middle estimate off by 6.7-fold (0.82 log units), on the high side, outside the stated range (below it).
By their numbers in this assay, from the lowest: compound 4; then compound 2; then compound 1; then compound 3.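

In this assay, thiophen-2-yl on the carbonyl carbon goes further than phenyl, with a 3.7-fold lower number from compound 2 to compound 4 (0.56 log units; beyond the scatter) for this exchange, so phenyl does not mark the low end of the numbers at this position. The same group stands further from the other two, with a 41-fold lower number from compound 1 to compound 4 (1.62 log units; beyond the scatter) against cyclopentyl and a 170-fold lower number from compound 3 to compound 4 (2.23 log units; beyond the scatter) against 2-chlorophenyl, the widest span yet seen at this place and one that leaves compound 4 as the most potent of the four. (No measurement shown here accounts for the gain of thiophen-2-yl over phenyl) Whether the gain extends to thiophen-3-yl, furan-2-yl or a pyridine on the carbonyl carbon remains open. Also open, going by these compounds, is whether chloro on the thiophen-2-yl ring would carry the same large cost as chloro on the phenyl.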